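Working notes: from compound 2 to compound 3

The compounds below may be only part of what the source reports. "The series", "measured", "known", "first", "only" and "open" are said of these compounds alone.

Measured in a functional assay on NCI-H1975 cells (Homo sapiens) for cytotoxicity, read by MTT assay, with a stated time of 72 h; on this read-out lower numbers stand for stronger inhibition and higher numbers for weaker inhibition:
- compound 1 `c1ccc(Nc2ncc3nc(Nc4ccccc4)n(C4CCCC4)c3n2)cc1`: > 10000 nM (a limit of the assay)
- compound 2 `Cc1cccc(Nc2nc3cnc(Nc4ccc(N5CCN(C)CC5)cc4)nc3n2C2CCCC2)c1`: 560 nM

Compound 1 is reported only as a limit, > 10000 nM. Within the data shown here, compound 2 gives 560 nM, the only actual number so far in this assay, so the series offers a single anchor and no ranking by size.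

Compound 3 `CN1CCN(c2ccc(Nc3ncc4nc(Nc5cc(Cl)ccc5Cl)n(C5CCCC5)c4n3)cc2)CC1` has 2,5-dichlorophenyl in place of 3-methylphenyl on a nitrogen on an aromatic ring.

Among the measured compounds shown here, no measured step between compounds differing in one place is available to calibrate this change. The working expectation is therefore no step beyond the scatter, with the direction left open. The expected step of a 1.1-fold lower number from compound 2 to compound 3 (0.05 log units; within the scatter) is an estimate anchored only on a single value. For compound 3 the estimate is 500 nM, with an expected range of 120 nM to 3000 nM.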

Compound 3, half-maximal inhibitory concentration: 2540 nM
Estimate against measurement, compound 3: 5.1-fold (0.71 log units) below, within the range that was stated.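

In this assay, the nitrogen on the aromatic ring now has its first readable step: 2,5-dichlorophenyl in place of 3-methylphenyl gives a 4.5-fold higher number from compound 2 to compound 3 (0.66 log units; beyond the scatter) and thus weaker inhibition. The read-out therefore responds to the aryl group at this place, and compound 3 at 2540 nM still gives an actual number rather than a limit of the assay. Nothing available on these compounds bears on what produces this step.

From the compounds shown here alone, the exchange adds both chlorines and removes the methyl in one move, so their separate contributions remain open. A 3-chlorophenyl or a 3-methoxyphenyl group on the same nitrogen would show whether the step follows the chlorines or the loss of the methyl.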